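Trading 2-Iodophenyl for 4-(Dimethylamino)phenyl on a Carbonyl

The source may hold more compounds than are shown below. What is called first, only, known or untested is meant among the compounds shown, and "the series" means these compounds.

Measured so far:
Compound 1, `CC(/C=N/Nc1ccc([N+](=O)[O-])cc1)=N\NC(=O)c1ccc(C(F)(F)F)cc1`, gives > 12000 nM in a functional assay on cells (Splenocyte, Mus musculus, strain BALB/c) for inhibition, read by scintillation counting and thymidine incorporation, with a stated time of 72 h (a lower number here means a stronger inhibitor, a higher number a weaker inhibitor), which is a limit of the assay rather than a number.
Compound 2, `CC(/C=N/Nc1ccc([N+](=O)[O-])cc1)=N\NC(=O)c1ccccc1I`, gives 2980 nM in this assay.

For the measured compounds named here, compound 2 therefore holds the only actual number in this set; the other entry sits at the limit (the limit of > 12000 nM in this assay, at which 1 of the 2 values shown sits). Compound 3, `CC(/C=N/Nc1ccc([N+](=O)[O-])cc1)=N\NC(=O)c1ccc(N(C)C)cc1`, has not yet been measured. It differs from compound 2 in a single place: 4-(dimethylamino)phenyl in place of 2-iodophenyl on a carbonyl carbon. Going by the values given here, no step between two measured compounds exists to calibrate a change of this kind, so the expectation rests on the two values alone. Compound 1, which shares the core, reaches only the limit (the limit of > 12000 nM in this assay, at which 1 of the 2 values shown sits). Against that background, compound 3 is expected to come out a weaker inhibitor than compound 2, with the step of a 2.7-fold higher number from compound 2 to compound 3 (0.43 log units; beyond the scatter) estimated to exceed the usual scatter. Compound 3 is estimated at 8000 nM, within a range from 2500 nM to 30000 nM, and a limit-only result would not be surprising.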

Compound 3, half-maximal inhibitory concentration: > 12000 nM
Compound 3: no number, only a limit; the forecaster's own chance of this, stated with the estimate: 40%; middle value at least 1.5-fold (0.17 log units) from the limit.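

For the compounds shown here, putting 4-(dimethylamino)phenyl in place of 2-iodophenyl on a carbonyl carbon gives an at least 4.0-fold higher number from compound 2 to compound 3 (0.60 log units; beyond the scatter), the first readable step at this position, and it shows that inhibition in this assay depends on which aromatic group sits there. Compound 3 carries a limit of the assay and not a number, as does compound 1, so the step from compound 1 to compound 3 cannot be read. Of the three compounds, only compound 2 gives an actual number, and the others stop at one ceiling: the limit of > 12000 nM in this assay, at which 2 of the 3 values shown sit.

Going by these compounds, whether the iodine itself is what keeps inhibition measurable in compound 2 remains open. A plain phenyl or a bromophenyl group on the same carbonyl carbon would help to separate the effect of the halogen from that of the aromatic ring.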